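Compound 3 to compound 4: acetyl to 3-cyanophenyl

This account rests on a few compounds, and the source may have more. Where it says the series, first, only, none or still open, it means among the compounds named here.

Within the data shown here, compound 3 `CC(=O)Cn1cc(CNC(=O)c2cnc(Nc3ccc(C#N)cc3)cc2Oc2c(C)cc(C)cc2C)nn1` gives 19400 nM in an ADME assay on MT4 cells (Homo sapiens) for cytotoxicity, read by MTT assay, with a stated time of 5 days (on this read-out lower numbers stand for higher toxicity in this test and higher numbers for lower toxicity in this test), the lowest number of the three so far. The nearest number belongs to compound 2 `Cc1ccc(Cn2cc(CNC(=O)c3cnc(Nc4ccc(C#N)cc4)cc3Oc3c(C)cc(C)cc3C)nn2)cc1`, at 165000 nM. Compound 1 `Cc1cc(C)c(Oc2cc(Nc3ccc(C#N)cc3)ncc2C(=O)NCc2cn(Cc3ccccc3[N+](=O)[O-])nn2)c(C)c1` reads > 212000 nM, which is a limit of this assay and not a number.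

Compound 4 `Cc1cc(C)c(Oc2cc(Nc3ccc(C#N)cc3)ncc2C(=O)NCc2cn(Cc3cccc(C#N)c3)nn2)c(C)c1` carries 3-cyanophenyl in place of acetyl on a saturated chain carbon bound to an aromatic nitrogen, the same difference reading 2-oxopropyl to 3-cyanobenzyl: 3-cyanophenyl in place of acetyl on a saturated chain carbon bound to an aromatic nitrogen.

Among the measured compounds shown here, two measured steps bear directly on this change, both running towards acetyl: an at least 10-fold lower number from compound 1 to compound 3 (1.03 log units; beyond the scatter), and an 8.5-fold lower number from compound 2 to compound 3 (0.93 log units; beyond the scatter). The third step, between the two compounds with an aromatic group at this place, is an at least 1.2-fold lower number from compound 1 to compound 2 (0.10 log units; that floor lies within the scatter). Compound 4 returns an aromatic group to this place, so the change should run opposite to those two steps. A higher number than that of compound 3 is therefore expected in this assay, beyond the scatter and similar in size to an 8.5-fold lower number from compound 2 to compound 3 (0.93 log units; beyond the scatter). The expected step is a 6.2-fold higher number from compound 3 to compound 4 (0.79 log units; beyond the scatter). For compound 4 the estimated value is 120000 nM, with an expected range of 40000 nM to 250000 nM. A limit in place of a number remains possible for compound 4.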

Compound 4, half-maximal cytotoxic concentration: >= 129000 nM
Compound 4: a limit, no number; the forecaster's own chance of this, stated with the estimate: 35%; middle value at least 1.0-fold (0.03 log units) from the limit.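

In this assay, 3-cyanophenyl in place of acetyl on a saturated chain carbon bound to an aromatic nitrogen gives an at least 6.6-fold higher number from compound 3 to compound 4 (0.82 log units; beyond the scatter). The separation of compound 3 from compounds 1 and 2 therefore also holds for a third aromatic group at this place, one carrying a nitrile in place of the nitro of compound 1 or the methyl of compound 2, and none of the four compounds shown goes against this. The value of compound 4 is a limit and not a number: the limit of >= 129000 nM in this assay, at which 1 of the 4 values shown sits.

The steps from compound 1 and from compound 2 to compound 4 cannot be read, and no order among 2-nitrophenyl, 4-methylphenyl and 3-cyanophenyl can be stated. Also open is whether the lower number belongs to acetyl alone or to groups without an aromatic ring more generally: among the compounds shown, acetyl is the only such group at this place, and an amine, a carboxylic acid or a longer alkyl chain on the same carbon would separate the two readings.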